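From (sec-butyl)amino to a charged ring

This account rests on a few compounds, and the source may have more. Where it says the series, first, only, none or still open, it means among the compounds named here.

Measured in a functional assay for inhibition, with Homo sapiens as the target; on this read-out higher numbers stand for an effect only at larger amounts of compound and lower numbers for an effect already at smaller amounts:
compound 1 `O=C1CCC(c2ccc(NC(=O)CCCCl)cc2)=NN1`: > 46.4 ug/mL
compound 2 `CC(C)NCC(=O)Nc1ccc(C2=NNC(=O)CC2)cc1`: about 46.4 ug/mL
compound 3 `CCC(C)NCC(=O)Nc1ccc(C2=NNC(=O)CC2)cc1`: about 21.5 ug/mL

The entry for compound 1 is a limit, not a number. Of the two true numbers, compound 3 has the lower, and compound 2 is its nearest neighbour.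

Compound 4 `C[N+]1(CC(=O)Nc2ccc(C3=NNC(=O)CC3)cc2)CCCC1` follows from compound 3 by one change: a group of 6 heavy atoms (5 carbon, 1 nitrogen; one five-membered non-aromatic ring with 1 hetero atom) in place of a group of 5 heavy atoms (4 carbon, 1 nitrogen; no ring), on a saturated chain carbon bound to a carbonyl carbon. The entering group has net charge +1.

Going by the values given here, two measured steps bear on this: an at least 2.1-fold lower number from compound 1 to compound 3 (0.33 log units; beyond the scatter), and a 2.2-fold lower number from compound 2 to compound 3 (0.33 log units; beyond the scatter). Neither covers such a group, so in this assay only a modest move towards higher numbers is expected. The expected step is a 2.1-fold higher number from compound 3 to compound 4 (0.33 log units; beyond the scatter). For compound 4 the estimate is 46 ug/mL, with an expected range of 15 ug/mL to 120 ug/mL.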

Compound 4, half-maximal effective concentration: > 46.4 ug/mL
Compound 4 gave a limit, no number; the forecaster's own chance of this, stated with the estimate: 50%; at least 1.0-fold (0.00 log units) between middle value and limit.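

In this assay, putting the five-membered ring of net charge +1 on the saturated chain carbon bound to a carbonyl carbon gives an at least 2.1-fold higher number from compound 3 to compound 4 (0.33 log units; beyond the scatter) and a number no lower from compound 2 to compound 4 (the limit leaves the size open). Going by these compounds alone, the lower number of compound 3 therefore does not carry over to this charged ring, a kind of group the earlier compounds did not show at this place. The size of the move stays unreadable, and the step from compound 1 cannot be read at all, because compound 4 gives only a limit: the limit of > 46.4 ug/mL in this assay, at which 2 of the 4 values shown sit.

On these data alone, whether the ring or the charge goes with this step remains open. So does how dimethylamino or a longer chain such as hexylamino would read on this carbon.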